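A few compounds are considered here, and "the series" means these few. Any claim that something is new, unique, unknown or untested is made for them only; others in the source may bear on it.

In a functional assay on PC-3 cells (Homo sapiens) for cytotoxicity, read by sulforhodamine B assay, with a stated time of 72 h (on this read-out higher numbers stand for weaker inhibition and lower numbers for stronger inhibition), compound 1 `Nc1sc(-c2ccc(Cl)cc2)c(-c2ccc(Cl)cc2)c1C(=O)NC1CCCCC1` gives 7300 nM. Compound 2 `Nc1sc(-c2ccc(Cl)cc2)c(-c2ccc(Cl)cc2)c1C(=O)N1CCCC1` differs from it by pyrrolidin-1-yl in place of cyclohexylamino on a carbonyl carbon, and that change makes the step of a 1.2-fold lower number from compound 1 to compound 2 (0.07 log units; within the scatter); in this assay compound 2 gives 6220 nM. Compound 3 `Nc1sc(-c2ccc(Br)cc2)c(-c2ccc(Cl)cc2)c1C(=O)NC1CCCCC1` carries a different core, differing from compound 1 by bromo in place of chloro on an aromatic carbon, which gives the step of a 3.9-fold higher number from compound 1 to compound 3 (0.59 log units; beyond the scatter); in this assay compound 3 gives 28400 nM. Compound 4 `Nc1sc(-c2ccc(Br)cc2)c(-c2ccc(Cl)cc2)c1C(=O)N1CCCC1` has not yet been measured; it differs from compound 3 by pyrrolidin-1-yl in place of cyclohexylamino on a carbonyl carbon, the same change as from compound 1 to compound 2 and at the same place. The step is expected to be a 1.2-fold lower number from compound 3 to compound 4 (0.07 log units; within the scatter), resting on the earlier step of a 1.2-fold lower number from compound 1 to compound 2 (0.07 log units; within the scatter), which stayed within the scatter. In this assay compound 4 is therefore estimated at 24000 nM, with a likely range from 11000 nM to 55000 nM.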

Compound 4, half-maximal inhibitory concentration: 37500 nM
Beside the measured number, compound 4's estimate is 1.6-fold (0.19 log units) below it; low and high end bracket the measured number.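

In this assay pyrrolidin-1-yl in place of cyclohexylamino gives a 1.3-fold higher number from compound 3 to compound 4 (0.12 log units; within the scatter) and behaves alike on both cores: the same change on two cores in this assay, a 1.2-fold lower number (0.07 log units; within the scatter) from compound 1 to compound 2 and a 1.3-fold higher number (0.12 log units; within the scatter) from compound 3 to compound 4, 1.5-fold (0.19 log units) apart, within the scatter of two such steps.

Bromo in place of chloro gives a 6.0-fold higher number from compound 2 to compound 4 (0.78 log units; beyond the scatter) and also matches its earlier step: the same change on two cores in this assay, a 3.9-fold higher number (0.59 log units; beyond the scatter) from compound 1 to compound 3 and a 6.0-fold higher number (0.78 log units; beyond the scatter) from compound 2 to compound 4, 1.5-fold (0.19 log units) apart, within the scatter of two such steps.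

So each change carried over between these two cores in this one assay, which does not show that it would carry over to any other core, nor why bromo gives the higher numbers.

The compounds shown leave open whether other amines on the carbonyl, such as morpholine or piperidine, would follow the same pattern. They also leave open how fluoro or methoxy would compare with chloro and bromo on the aromatic carbon.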